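Three Limits and an Untested Ortho-Methoxy Analogue

The source may hold more compounds than are shown below. What is called first, only, known or untested is meant among the compounds shown, and "the series" means these compounds.

Compound 1 `COc1cccc(/C=C/C(=O)c2ccc(OC)c3c2OC(C)(C)C=C3)c1` was tested in a functional assay on HT-29 cells (Homo sapiens) for antiproliferative activity, read by MTT assay, with a stated time of 24 h (a higher number here means a weaker inhibitor, a lower number a stronger inhibitor), where compound 1 gives only a limit of the assay, > 10000 nM. Compound 2 `COc1ccc(C(=O)/C=C/c2cccc(Cl)c2)c2c1C=CC(C)(C)O2` likewise gives a limit in this assay, > 10000 nM. Compound 3 `COc1ccc(C(=O)/C=C/c2ccccc2Cl)c2c1C=CC(C)(C)O2` also gives a limit there, > 10000 nM. Compound 3 differs from compound 2 in how the same atoms are joined: 2-chlorophenyl in place of 3-chlorophenyl on a double-bonded chain carbon bound to a double-bonded chain carbon. The step that the two limits leave unreadable from compound 2 to compound 3 cannot be read, nor can a step that the two limits leave unreadable from compound 1 to compound 3. Compound 1 arises from compound 2 by methoxy in place of chloro on an aromatic carbon, a step that the two limits leave unreadable from compound 2 to compound 1 whose size is hidden because of the limit of > 10000 nM in this assay, at which 3 of the 3 values shown sit.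

Compound 4 `COc1ccccc1/C=C/C(=O)c1ccc(OC)c2c1OC(C)(C)C=C2` has not been measured; it arises from compound 3 by methoxy in place of chloro on an aromatic carbon. This is the same kind of change as from compound 2 to compound 1, though there the methoxy sits meta to a large group and here ortho to a large group. With the earlier step unreadable, the expected step that the limit leaves unreadable from compound 3 to compound 4 rests on the three limits alone. Compound 4 is therefore expected to give 20000 nM in this assay, most probably again as a limit.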

Compound 4, half-maximal inhibitory concentration: > 10000 nM
Compound 4 was reported as a limit; the forecaster's own chance of this, stated with the estimate: 80%; the middle value is on the limit's open side.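

No step between compound 4 and compound 1, compound 2 or compound 3 can be read in this assay, because the values offer no number to compare: the limit of > 10000 nM in this assay, at which 4 of the 4 values shown sit.

The compounds shown leave open whether chloro and methoxy groups differ at all in their effect on this activity.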